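A tert-butyl group added to a compound at the limit

The compounds below may be only part of what the source reports. "The series", "measured", "known", "first", "only" and "open" are said of these compounds alone.

Measured in an ADME assay on BaF3 cells (Mus musculus) for cytotoxicity, read by MTT assay, with a stated time of 48 h; on this read-out lower numbers stand for stronger inhibition of growth and higher numbers for weaker inhibition of growth:
compound 1 `CC(C)n1nc(-c2cc(C3CCCCC3)on2)c2c(N)ncnc21`: > 10000 nM, a limit
compound 2 `CC(C)n1nc(-c2ccon2)c2c(N)ncnc21`: > 10000 nM, a limit

Compound 2 has no exact number in this assay, only the limit > 10000 nM. Compound 1 sits at the same limit, as the limit of > 10000 nM in this assay, at which 2 of the 2 values shown sit, shows. Compound 3 `CC(C)n1nc(-c2cc(C(C)(C)C)on2)c2c(N)ncnc21` differs from compound 2 by one change, tert-butyl in place of hydrogen on an aromatic carbon. Going by the values given here, the one measured step that bears on this is a step that the two limits leave unreadable from compound 1 to compound 2, which also changes the group on an aromatic carbon, but its size cannot be read. Compound 1, which carries cyclohexyl there, gives only the limit > 10000 nM. A step beyond the usual scatter is therefore not expected, in either direction. Compound 3 is expected at 10000 nM, with an estimated range of 4000 nM to 30000 nM. This estimate means an expected a number no higher from compound 2 to compound 3 (the limit leaves the size open).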

Compound 3, concentration for 50% growth inhibition: > 10000 nM
Compound 3: only a limit was reported; the forecaster's own chance of this, stated with the estimate: 80%; the middle value sits exactly at the limit.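

Compound 3 gives a limit and not a number, like compound 1 and compound 2, so no step among these three compounds can be read: the limit of > 10000 nM in this assay, at which 3 of the 3 values shown sit. Left open is how strongly each inhibits growth, and whether hydrogen, tert-butyl or cyclohexyl on this aromatic carbon makes any difference.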